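The source may hold more compounds than are shown below. What is called first, only, known or untested is meant among the compounds shown, and "the series" means these compounds.

Compounds measured so far:
compound 1 `Cc1noc(Cc2ccc3[nH]cc([C@H]4C[C@H](N(C)C)C4)c3c2)n1` with 933 nM
compound 2 `Cc1nc(Cc2ccc3[nH]cc([C@H]4C[C@H](N(C)C)C4)c3c2)n[nH]1` with 2040 nM
compound 3 `CN(C)[C@H]1C[C@H](c2c[nH]c3ccc(CC(N)=O)cc32)C1` with 724 nM

All three share a core and differ only in the group on the saturated chain carbon bound to the aromatic carbon. In an assay on CHO-K1 cells for binding affinity to 5-hydroxytryptamine receptor 1D (Homo sapiens) (a higher number here means a weaker inhibitor, a lower number a stronger inhibitor), compound 3 holds the lowest of the three numbers, though its nearest neighbour is within the scatter: the step of a 1.3-fold lower number from compound 1 to compound 3 (0.11 log units; within the scatter) shows no real separation between compound 1 and compound 3, whereas a 2.8-fold lower number from compound 2 to compound 3 (0.45 log units; beyond the scatter) and a 2.2-fold higher number from compound 1 to compound 2 (0.34 log units; beyond the scatter) set compound 2 apart as the weaker of the three.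

Compound 4 `Cc1noc(-c2ccc3[nH]cc([C@H]4C[C@H](N(C)C)C4)c3c2)n1` differs from compound 3 by 3-methyl-1,2,4-oxadiazol-5-yl in place of carbamoylmethyl on an aromatic carbon. Two things change at once here: the carbamoyl group gives way to the methyl-oxadiazole, and the intervening saturated chain carbon is gone, so the ring now sits directly on the aromatic carbon. The first part is covered by the step from compound 1 to compound 3, which was small; the second part, the loss of the saturated chain carbon, has no measured counterpart among these compounds. With the exchange of the terminal group itself having moved this assay little, compound 4 is expected to land near compound 1 and compound 3, and the step of a 1.2-fold higher number from compound 3 to compound 4 (0.09 log units; within the scatter) is estimated to stay within or only modestly beyond the scatter. The estimate for compound 4 is 900 nM, in a range from 300 nM to 2700 nM.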

Compound 4, half-maximal inhibitory concentration: 562 nM
Compound 4: middle estimate off by 1.6-fold (0.20 log units), on the high side, and the stated range covers the measured number.
By their numbers in this assay, from the lowest: compounds 4, 3 and 1 (each within the scatter of the next); then compound 2.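

In this assay, going by these compounds alone, the pair of compound 1 and compound 4 shows what the earlier compounds could not: with the 3-methyl-1,2,4-oxadiazol-5-yl group kept, removing the saturated chain carbon so that the ring sits directly on the aromatic carbon gives a 1.7-fold lower number from compound 1 to compound 4 (0.22 log units; within the scatter) and so produces no real separation. Exchanging carbamoylmethyl for this directly attached ring gives a 1.3-fold lower number from compound 3 to compound 4 (0.11 log units; within the scatter) and likewise leaves the two compounds indistinguishable, while a 3.6-fold lower number from compound 2 to compound 4 (0.56 log units; beyond the scatter) confirms that compound 2, with its (5-methyl-1H-1,2,4-triazol-3-yl)methyl group, is the only one of the four set apart, as the weakest. Nothing available bears on the reason for these results.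

Going by these compounds, it remains open whether the 5-methyl-1H-1,2,4-triazol-3-yl ring, placed directly on the aromatic carbon, would stay apart from compound 4 in this assay or fall level with it. Also open, on these data alone, is how a longer chain, a primary amine or a carboxylic acid at this position would behave, since the four compounds span only a narrow range of groups here.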